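Oxan-4-yl on the sulfonyl sulfur: clearance expectation

The compounds below may be only part of what the source reports. "The series", "measured", "known", "first", "only" and "open" are said of these compounds alone.

Compound 1 `Cc1ccc2[nH]c(C(=O)N[C@H]3CN(S(=O)(=O)c4cccnc4)C[C@@H]3C(=O)NCCN(C)C)cc2c1` and compound 2 `Cc1ccc2[nH]c(C(=O)N[C@H]3CN(S(=O)(=O)c4ccnc(C)c4)C[C@@H]3C(=O)NCCN(C)C)cc2c1` share one core and differ only in the group on the sulfonyl sulfur. In an ADME assay on cells (Hepatocyte, Rattus norvegicus) for metabolic stability (on this read-out higher numbers stand for fast clearance and lower numbers for slow clearance), compound 1 gives 8 uL/min, and in this assay compound 2 gives 8 uL/min. The single measured step, no change at the digits printed from compound 1 to compound 2 (within the scatter), is flat, so compound 2 stands level with compound 1 at the digits shown.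

Compound 3 `Cc1ccc2[nH]c(C(=O)N[C@H]3CN(S(=O)(=O)C4CCOCC4)C[C@@H]3C(=O)NCCN(C)C)cc2c1` is still unmeasured. Its difference from compound 2 is oxan-4-yl in place of 2-methylpyridin-4-yl on a sulfonyl sulfur. Going by the values given here, the only step that bears on it sits at the same sulfonyl sulfur, and that step, no change at the digits printed from compound 1 to compound 2 (within the scatter), showed nothing beyond the scatter. Among the compounds with values here, that step, however, exchanged one aromatic ring for another; no measured step covers the entry of a non-aromatic ring, so the range is kept wide.

Compound 3 is therefore expected near 8 uL/min, with a range from 4 uL/min to 18 uL/min. The estimated step of no change at the digits printed from compound 2 to compound 3 (within the scatter) is expected to stay within the scatter.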

Compound 3, intrinsic clearance in a liver preparation (reported as CLH), per the amount of preparation that the assay uses: 4 uL/min
Compound 3: the middle estimate sits 2.0-fold (0.30 log units) above what was measured; the measured number falls inside the stated range.
By their numbers in this assay, from the lowest: compounds 3, 1 and 2 (each within the scatter of the next).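

In this assay, going by these compounds alone, oxan-4-yl in place of 2-methylpyridin-4-yl gives a 2.0-fold lower number from compound 2 to compound 3 (0.30 log units; within the scatter) and oxan-4-yl in place of pyridin-3-yl gives a 2.0-fold lower number from compound 1 to compound 3 (0.30 log units; within the scatter) and these are the first steps at the sulfonyl sulfur that go from a six-membered aromatic ring to a six-membered non-aromatic ring. Both steps stay within the scatter, so this read-out does not separate the oxan-4-yl compound from either aromatic compound, and the ring hetero atom can be oxygen or nitrogen with all three compounds level. Nothing measured here offers an explanation for this flat result.

Open, going by these compounds, is whether a group without a ring on the sulfonyl sulfur, such as a short alkyl chain, would stay level with these three compounds. Also open, on these data alone, is whether a ring carrying an amine or a carboxylic acid at this position would do the same.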